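The source may report more compounds than this note shows. Statements on the series, on what has been measured and on what is new or still open speak of the compounds shown alone.

Compound 1 `Cn1c(Cc2nn(C)c(=O)c3ccccc23)nnc1SCCCCCCCC(=O)Nc1ccc(Cl)cc1Cl` is the reference of this set. In an assay on NK92 cells for inhibition of interleukin-2 (Homo sapiens), read by AlphaScreen, with stated times of 30 min and 1 h (on this read-out higher numbers stand for weaker inhibition and lower numbers for stronger inhibition), compound 1 gives 350 nM. Compound 2 `Cn1c(Cc2nn(CCCO[Si](C)(C)C(C)(C)C)c(=O)c3ccccc23)nnc1SCCCCCCCC(=O)Nc1ccc(Cl)cc1Cl` carries a longer chain on the same nitrogen. For compound 2 the result in this assay is a limit of the assay, > 30000 nM, and not a number. Compound 3 `CN(C)CCCn1nc(Cc2nnc(SCCCCCCCC(=O)Nc3ccc(Cl)cc3Cl)n2C)c2ccccc2c1=O` puts a 3-(dimethylamino)propyl in the same position. For compound 3 the result in this assay is likewise a limit, > 30000 nM, not a number. Compound 3 therefore stands at the limit of > 30000 nM in this assay, at which 2 of the 3 values shown sit, and the numbers do not rank it against compound 2. The two measured steps that reach this limit are an at least 85-fold higher number from compound 1 to compound 2 (1.93 log units; beyond the scatter) and an at least 85-fold higher number from compound 1 to compound 3 (1.93 log units; beyond the scatter); between the two substituted compounds the step is a step that the two limits leave unreadable from compound 2 to compound 3. Compound 4 `Cn1c(Cc2nn(CCCO)c(=O)c3ccccc23)nnc1SCCCCCCCC(=O)Nc1ccc(Cl)cc1Cl` is obtained by the change (hydroxy in place of dimethylamino on a saturated chain carbon, three bonds along the chain from an aromatic nitrogen). Since both steps away from compound 1 are large, a smaller end group on the same chain is not expected to bring the number back to that of compound 1, though it may fall short of the limit. Compound 4 is therefore expected to remain weak, with the step of an at least 2.5-fold lower number from compound 3 to compound 4 (0.39 log units; beyond the scatter) expected to be modest. The estimate for compound 4 is 12000 nM, within 2000 nM to 30000 nM.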

Compound 4, half-maximal inhibitory concentration: > 30000 nM
Compound 4: no number, only a limit (the forecaster's own chance of this, stated with the estimate: 40%); middle value at least 2.5-fold (0.39 log units) away from the limit.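

In this assay compound 4 gives > 30000 nM, which is again a limit of the assay and not a number. Replacing dimethylamino with hydroxy, the 3-hydroxypropyl chain still leaves an at least 85-fold higher number from compound 1 to compound 4 (1.93 log units; beyond the scatter), so the large loss seen against compound 1 is not confined to the dimethylamino and silicon-bearing end groups but also appears with the hydroxy end, the one with the fewest heavy atoms of the three. The steps among compound 2, compound 3 and compound 4 cannot be read, so these three end groups cannot be ranked against one another, and all that can be said is that they share one ceiling: the limit of > 30000 nM in this assay, at which 3 of the 4 values shown sit.

The compounds shown leave open where, between the methyl of compound 1 and the substituted propyl chains, the number starts to rise, which an ethyl or a plain propyl at this position would help to settle. They also leave open whether another end group on the propyl chain, such as a carboxylic acid or a primary amide, would give a number below the limit.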